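The source may hold more compounds than are shown below. What is called first, only, known or untested is meant among the compounds shown, and "the series" means these compounds.

Compound 1 `CC(C)[C@H](NC(=O)c1cc(Cl)ccc1O)C(=O)Nc1ccc(Cl)cc1`: > 10000 nM, a limit
Compound 2 `CC(C)[C@H](NC(=O)c1ccc(Cl)cc1O)C(=O)Nc1ccc(Cl)c(Cl)c1`: > 10000 nM, a limit
Compound 3 `C[C@H](NC(=O)c1ccc(Cl)cc1O)C(=O)Nc1ccc(C(F)(F)F)cc1`: > 12500 nM, a limit

All three compounds were tested in a functional assay on MCF7 cells (Homo sapiens) for cytotoxicity, with a stated time of 72 h (on this read-out higher numbers stand for weaker inhibition and lower numbers for stronger inhibition), and none returned a number. Compound 1 stands at a limit, > 10000 nM, as do the other two compounds at their own limits. Compound 4 `CC(C)[C@H](NC(=O)c1cc(Cl)ccc1O)C(=O)Nc1cccc(Cl)c1` keeps the core of compound 1, with 3-chlorophenyl in place of 4-chlorophenyl on an amide-type nitrogen. Among the measured compounds shown here, no step between measured compounds is available in this assay, so the expectation rests on compound 1 alone. The estimated step of a number no higher from compound 1 to compound 4 (the limit leaves the size open) is expected to stay within the usual scatter, in neither direction. For compound 4 the estimated value is 10000 nM, with an expected range from 5000 nM to 20000 nM.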

Compound 4, half-maximal inhibitory concentration: > 10000 nM
Compound 4 ended at the assay's limit; the forecaster's own chance of this, stated with the estimate: 85%; the middle value lies on the limit itself.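

Compound 1 and compound 4 both end at a limit in this assay, so the step between them cannot be read. The compounds shown leave open whether 3-chlorophenyl and 4-chlorophenyl differ at all in this read-out.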